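Swapping methoxy for fluoro at an assay limit

A few compounds are considered here, and "the series" means these few. Any claim that something is new, unique, unknown or untested is made for them only; others in the source may bear on it.

In a functional assay on M21 cells (Homo sapiens) for antiproliferative activity, read by sulforhodamine B assay, with a stated time of 48 h (on this read-out lower numbers stand for stronger inhibition and higher numbers for weaker inhibition), compound 1 (`CN1CCN(c2ccc(S(=O)(=O)Oc3cccc(Br)c3)cc2)C1=O`) reads 1300 nM and compound 2 (`CN1CCN(c2ccc(S(=O)(=O)Oc3cccc(I)c3)cc2)C1=O`) reads 400 nM on the same scale. Compound 3 (`COc1ccc(OS(=O)(=O)c2ccc(N3CCN(C)C3=O)cc2)cc1`) gives no number, only a limit (> 100000 nM). Compound 4 (`CN1CCN(c2ccc(S(=O)(=O)Oc3ccc(F)cc3)cc2)C1=O`) is still unmeasured, and it carries fluoro in place of methoxy on an aromatic carbon, para to a large group (fluoro in place of methoxy on an aromatic carbon). Among the compounds with values here, no measured step makes this exact change. The closest evidence is large, with an at least 76-fold higher number from compound 1 to compound 3 (1.88 log units; beyond the scatter) and an at least 250-fold higher number from compound 2 to compound 3 (2.39 log units; beyond the scatter) as the changes on leaving 3-bromophenyl and 3-iodophenyl for 4-methoxyphenyl. The halogen exchange is only modest, at a 3.3-fold lower number from compound 1 to compound 2 (0.51 log units; beyond the scatter) in this assay. Compound 4 has a halogen, as compounds 1 and 2 do, but in the 4-fluorophenyl group, so only a partial recovery is expected. The expected change is an at least 5.0-fold lower number from compound 3 to compound 4 (0.69 log units; beyond the scatter) toward a lower number, and its true size may remain hidden by the limit. For compound 4 the estimated value is 20000 nM, with an expected range from 3000 nM to 100000 nM in this assay.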

Compound 4, half-maximal inhibitory concentration: > 100000 nM
Compound 4: a limit, no number; the forecaster's own chance of this, stated with the estimate: 45%; middle value at least 5.0-fold (0.69 log units) from the limit.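

In this assay compound 4 gives > 100000 nM, which is a limit of the assay and not a number. Fluoro in place of methoxy on this aromatic carbon, para to a large group, therefore brings back no measurable reading, and a halogen in the 4-fluorophenyl group does not match the 3-iodophenyl or 3-bromophenyl compounds, with an at least 250-fold higher number from compound 2 to compound 4 (2.39 log units; beyond the scatter) and an at least 76-fold higher number from compound 1 to compound 4 (1.88 log units; beyond the scatter). The step from compound 3 to compound 4 cannot be read, and any difference between these two compounds stays hidden: the limit of > 100000 nM in this assay, at which 2 of the 4 values shown sit.

Going by these compounds, it remains open whether the identity of the halogen or its place on the ring decides the outcome, and a 4-iodophenyl group would bear on that question. On these data alone, how an amine or a nitrile on this same carbon would read in this assay is also open.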